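The source may report more compounds than this note shows. Statements on the series, on what has been measured and on what is new or still open speak of the compounds shown alone.

Compound 1 `Cc1nn(-c2cccc(CN)c2)c2c(F)c(-c3ccc(N4CCCC4=O)cc3)ccc12` gives 702 nM in an assay on isolated protein for inhibition of Trypsin (Homo sapiens); on this read-out lower numbers stand for stronger inhibition and higher numbers for weaker inhibition.
Compound 2 `Nc1noc2ccc(-n3nc(C(F)(F)F)c4ccc(-c5ccc(N6CCCCC6=O)cc5F)c(F)c43)cc12` gives > 10000 nM in this assay, which is a limit of the assay and not a number.
Compound 3 `CN(C)Cc1[nH]ncc1-c1ccc(-c2ccc3c(C(N)=O)nn(-c4ccc5onc(N)c5c4)c3c2F)c(F)c1` gives > 10000 nM in this assay, likewise a limit of the assay rather than a number.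

Compound 3 therefore stands at the limit of > 10000 nM in this assay, at which 2 of the 3 values shown sit; only compound 1 has a numerical value. Compound 4 `CN(C)Cc1cnccc1-c1ccc(-c2ccc3c(C(N)=O)nn(-c4ccc5onc(N)c5c4)c3c2F)c(F)c1` differs from compound 3 by 3-((dimethylamino)methyl)pyridin-4-yl in place of 5-((dimethylamino)methyl)-1H-pyrazol-4-yl on an aromatic carbon. Among the compounds with values here, no step between measured compounds is available, so the size of this change in this assay cannot be anchored. The step from compound 3 to compound 4 is expected as a step that the limit leaves unreadable from compound 3 to compound 4, most likely none beyond the scatter, with the value remaining at the limit. Compound 4 is estimated at 20000 nM, within 5000 nM to 80000 nM.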

Compound 4, inhibition constant: > 10000 nM
Compound 4: only a limit was reported; the forecaster's own chance of this, stated with the estimate: 80%; the middle value is on the limit's open side.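

Compound 3 and compound 4 both give limits rather than numbers in this assay, so no step between them can be read: the limit of > 10000 nM in this assay, at which 3 of the 4 values shown sit.

The compounds shown leave open whether 3-((dimethylamino)methyl)pyridin-4-yl in place of 5-((dimethylamino)methyl)-1H-pyrazol-4-yl changes trypsin inhibition at all.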